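This account rests on a few compounds, and the source may have more. Where it says the series, first, only, none or still open, it means among the compounds named here.

Compounds measured in a functional assay on PC-3 cells (Homo sapiens) for inhibition; a higher number here means a weaker inhibitor, a lower number a stronger inhibitor:
compound 1, `Cc1c(C(=O)N/N=C\c2cc(F)ccc2O)oc2cccc(O)c12`, 3170 nM;
compound 2, `Cc1ccc(O)c(/C=N\NC(=O)c2oc3cccc(O)c3c2C)c1`, 7350 nM.

Among the measured compounds shown here, compound 2 gives the highest of the two numbers in this assay; its nearest neighbour is compound 1, reached by a 2.3-fold higher number from compound 1 to compound 2 (0.37 log units; beyond the scatter), the only step measured, and that step is a modest one. Compound 3, `Cc1c(C(=O)N/N=C\c2cccc(F)c2)oc2cccc(O)c12`, is not yet measured. It differs from compound 2 by 3-fluorophenyl in place of 2-hydroxy-5-methylphenyl on a carbon with a double bond to nitrogen. For the measured compounds named here, the measured step bears on it only in part: fluoro returns where methyl had stood, which on its own points back toward the number of compound 1, but the loss of the hydroxyl from the leaving group has no counterpart among the measured compounds. Compound 3 is therefore expected to show a modest step downward, a 1.8-fold lower number from compound 2 to compound 3 (0.26 log units; within the scatter), with a wide range. The estimate for compound 3 in this assay is 4000 nM, between 1500 nM and 12000 nM.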

Compound 3, half-maximal inhibitory concentration: >= 40000 nM
Compound 3: no number, only a limit (the forecaster's own chance of this, stated with the estimate: 5%); middle value at least 10-fold (1.00 log units) away from the limit.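

In this assay, compound 3 gives no number, only a limit: the limit of >= 40000 nM in this assay, at which 1 of the 3 values shown sits.

Hydrogen in place of hydroxy on an aromatic carbon, the single change at this position, gives an at least 12-fold higher number from compound 1 to compound 3 (1.10 log units; beyond the scatter), a large step, so the hydroxy on this ring weighs far more in this series than the fluoro-to-methyl change did. The full replacement of 2-hydroxy-5-methylphenyl by 3-fluorophenyl on a carbon with a double bond to nitrogen gives an at least 5.4-fold higher number from compound 2 to compound 3 (0.73 log units; beyond the scatter), so neither of the two hydroxy-bearing compounds comes close to the limit.

Going by these compounds, the true size of both steps stays unknown, as each ends at a limit. The compounds shown also leave open whether an amine or a methoxy group in place of that hydroxy would keep the number near that of compound 1.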